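The source may hold more compounds than are shown below. What is called first, only, known or untested is meant among the compounds shown, and "the series" means these compounds.

Two esters built on one shared core have been tested in a functional assay on B16 cells (Mus musculus) for inhibition; a higher number here means a weaker inhibitor, a lower number a stronger inhibitor. Compound 1 `COc1cc2oc(=O)cc(COC(=O)/C=C/c3ccccc3)c2cc1OC` gives > 10 ug/mL, which is a limit and not a number. Compound 2 `COc1cc2oc(=O)cc(COC(=O)/C=C/c3ccc(Cl)cc3)c2cc1OC` gives > 10 ug/mL, which is also a limit. Compound 2 therefore stands at the limit of > 10 ug/mL in this assay, at which 2 of the 2 values shown sit, with no numerical reading on either compound.

The next compound, compound 3 `COc1cc2oc(=O)cc(COC(=O)/C=C/c3ccc(O)cc3)c2cc1OC`, carries hydroxy in place of chloro on an aromatic carbon, para to a large group: hydroxy in place of chloro on an aromatic carbon. For the measured compounds named here, only one measured step bears on this position, namely a step that the two limits leave unreadable from compound 1 to compound 2, where chloro took the place of hydrogen on an aromatic carbon. That step has no readable size, so it offers no magnitude to carry over to the new change. No definite direction can therefore be expected in this assay, and another limit reading remains a likely outcome. The expected change is only a loose estimate: a step that the limit leaves unreadable from compound 2 to compound 3. Compound 3 is estimated at 15 ug/mL, with an expected range of 5 ug/mL to 50 ug/mL.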

Compound 3, half-maximal inhibitory concentration: 4.15 ug/mL
Estimate against measurement, compound 3: 3.6-fold (0.56 log units) above; measured number outside the range, below it.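

In this assay, compound 3 is the only one of the three esters shown that gives a number rather than a limit, so a group on this aromatic carbon, para to a large group, can move the reading. Hydroxy in place of chloro gives an at least 2.4-fold lower number from compound 2 to compound 3 (0.38 log units; beyond the scatter), and hydroxy in place of hydrogen gives an at least 2.4-fold lower number from compound 1 to compound 3 (0.38 log units; beyond the scatter); both steps are measured against limits, so each gives only the smallest size the data allow. The 4-hydroxyphenyl ester thus stands apart from both the 4-chlorophenyl ester and the unsubstituted ester, whose own step cannot be read, and these two remain unresolved at the top of the range: the limit of > 10 ug/mL in this assay, at which 2 of the 3 values shown sit.

The compounds shown leave open whether this shift is particular to hydroxy or would also appear with an amine, a methoxy group or a carboxylic acid at the same place. From the compounds shown here alone, how much larger the two steps really are also stays open, as does whether an amide in place of the ester would keep the reading of compound 3.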